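Swapping the piperazine cap: imidazolylmethyl to pyrimidinyl

The source may hold more compounds than are shown below. What is called first, only, known or untested is meant among the compounds shown, and "the series" means these compounds.

Compound 1: `c1c[nH]c(CN2CCN(CCCc3c[nH]c4ccc(-n5cnnc5)cc34)CC2)n1` with 36 nM in an assay on CHO cells for displacement of a labelled ligand from 5-hydroxytryptamine receptor 1B (Homo sapiens); a lower number here means a stronger inhibitor, a higher number a weaker inhibitor
Compound 2: `CN(C)C(=O)C(c1ccccc1)N1CCN(CCCc2c[nH]c3ccc(-n4cnnc4)cc23)CC1` with 102 nM in this assay
Compound 3: `CN1CCN(CCCCc2c[nH]c3ccc(-n4cnnc4)cc23)CC1` with 5100 nM in this assay

Three compounds share a core and differ in what sits on the distal nitrogen of the six-membered ring and in the length of the linking chain. Compound 1 gives the lowest number of the three in this assay, and its distance to compound 2 and to compound 3 is beyond the usual scatter, so compound 1 is the strongest inhibitor in this set. Compound 3 stands far above both.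

Compound 4, `c1cnc(N2CCN(CCCc3c[nH]c4ccc(-n5cnnc5)cc34)CC2)nc1`, has not yet been measured. It differs from compound 1 by pyrimidin-2-yl in place of (1H-imidazol-2-yl)methyl on an amine nitrogen in a ring. Here an aromatic ring is attached directly to the ring nitrogen instead of through a methylene, and a hydrogen-bond donor is exchanged for a second acceptor. Nothing measured in this set tells how such a change plays out, so only a modest shift in either direction, or none beyond the scatter, is expected. The estimate for compound 4 is 50 nM, with a range of 10 nM to 250 nM, meaning an expected step of a 1.4-fold higher number from compound 1 to compound 4 (0.14 log units; within the scatter).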

Compound 4, half-maximal inhibitory concentration: 0.5 nM
For compound 4 the middle estimate is 100-fold (2.00 log units) above the measured one; measured number outside the range, below it.
By their numbers in this assay, from the lowest: compound 4; then compound 1; then compound 2; then compound 3.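

The group on the amine nitrogen in the ring has a strong hold on the number in this assay: pyrimidin-2-yl in place of (1H-imidazol-2-yl)methyl gives a 72-fold lower number from compound 1 to compound 4 (1.86 log units; beyond the scatter), a large step beyond the scatter. Going by these compounds alone, the earlier compounds differed in more than one place, so this pair is the first to isolate that nitrogen, and the step arises even though the two groups have the same count of heavy atoms and the same count of ring hetero atoms. Nothing measured here accounts for the size of this step.

The step combines three changes: ring size, loss of the methylene, and the exchange of a hydrogen-bond donor for an acceptor. Pyrimidin-2-ylmethyl or directly attached 1H-imidazol-2-yl on the same nitrogen would help separate them, and how either would read in this assay remains open.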